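This account rests on a few compounds, and the source may have more. Where it says the series, first, only, none or still open, it means among the compounds named here.

Compound 2 `COc1ccc(-n2nc(Sc3ccc(Cl)cc3)cc(CC[C@@H](C)NC(=O)[C@H]3CNC[C@@H]3c3ccccc3F)c2=O)cc1` is compared here with compound 1 `COc1ccc(-n2nc(Sc3ccc(Cl)cc3)cc(CC[C@@H](C)NC(=O)[C@H]3CCNC[C@@H]3c3ccccc3F)c2=O)cc1`, which differs in the size of its saturated ring. In a functional assay with Melanocortin receptor 4 (Homo sapiens) as the target, read by cAMP accumulation (a higher number here means that more compound is needed for the effect, a lower number that less compound is needed), compound 2 gives 710 nM, while compound 1 gives 550 nM; the two values lie within the usual scatter of each other, so neither can be set apart. Compound 3 `COc1ccc([C@H]2CNC[C@@H]2C(=O)N[C@H](C)CCc2cc(Sc3ccc(Cl)cc3)nn(-c3ccc(OC)cc3)c2=O)cc1` carries the change (4-methoxyphenyl in place of 2-fluorophenyl on a saturated ring carbon). Within the data shown here, no measured pair shows the effect of such a swap, so only a modest step is expected, tending toward a higher number. Compound 3 is therefore expected to give 1000 nM, between 300 nM and 3000 nM, a step of a 1.4-fold higher number from compound 2 to compound 3 (0.15 log units; within the scatter).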

Compound 3, half-maximal effective concentration: 430 nM
Compound 3: middle estimate off by 2.3-fold (0.37 log units), on the high side; measured number inside the range.
By their numbers in this assay, from the lowest: compounds 3, 1 and 2 (each within the scatter of the next).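

In this assay, putting 4-methoxyphenyl in place of 2-fluorophenyl on the saturated ring carbon gives a 1.7-fold lower number from compound 2 to compound 3 (0.22 log units; within the scatter) and so stays within the scatter. This position, two ring bonds from the ring nitrogen, therefore takes a group with one more heavy atom and one hydrogen-bond acceptor without a step that can be set apart. Nothing available explains this result.
Still open, as far as these compounds go, is whether a carboxylic acid or an amine on this aromatic ring, or a cyclohexyl group in its place, would give a step beyond the scatter.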